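A few compounds are considered here, and "the series" means these few. Any claim that something is new, unique, unknown or untested is made for them only; others in the source may bear on it.

Compound 1 `COc1ccc([C@H]2CC(=O)N(c3cccc(N)c3C)C2)cc1OC1CCCC1`: in a functional assay on HEK293 cells (Homo sapiens) for cytotoxicity (a lower number here means that less compound is tolerated, a higher number that more compound is tolerated), compound 1 gives > 10000 nM, a limit of the assay.
Compound 2 `COc1ccc([C@H]2CC(=O)N(c3ccc(C)cc3)C2)cc1OC1CCCC1`: compound 2 gives > 10000 nM, also a limit.
Compound 3 `COc1ccc([C@H]2CC(=O)N(c3cccc(NCCCc4ccccc4)c3)C2)cc1OC1CCCC1`: compound 3 gives > 10000 nM, again a limit.

Compound 3 therefore stands at the limit, together with all other measured compounds (the limit of > 10000 nM in this assay, at which 3 of the 3 values shown sit). Compound 4 `COc1ccc([C@H]2CC(=O)N(c3cccc(NS(=O)(=O)c4cc(Br)c(Cl)s4)c3)C2)cc1OC1CCCC1` differs from it in one place: (4-bromo-5-chlorothiophen-2-yl)sulfonyl in place of 3-phenylpropyl on a nitrogen on an aromatic ring. Within the data shown here, the only step between measured compounds, a step that the two limits leave unreadable from compound 1 to compound 2, joins two limits and gives no readable size, and it concerns a different part of the shared core. There is thus no measured evidence that points in either direction for this change. The step of a number no higher from compound 3 to compound 4 (the limit leaves the size open) is expected to show no movement beyond the scatter, with compound 4 most likely remaining at the limit. The estimate for compound 4 is 10000 nM, in the range 5000 nM to 30000 nM.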

Compound 4, half-maximal cytotoxic concentration: > 10000 nM
Compound 4 ended at the assay's limit; the forecaster's own chance of this, stated with the estimate: 80%; the middle value sits exactly at the limit.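

Compound 3 and compound 4 both stand at the limit in this assay, so no size can be read for the change between them: the limit of > 10000 nM in this assay, at which 4 of the 4 values shown sit.

The compounds shown leave open how much compound is tolerated beyond that limit, and whether any of these changes alters it.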